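The source may hold more compounds than are shown below. What is called first, only, known or untested is meant among the compounds shown, and "the series" means these compounds.

Measured compounds:
- compound 1, `Nc1sc(-c2ccc(Cl)cc2)c(-c2ccc(Cl)cc2)c1C(=O)NC1CCCCC1`, giving 7300 nM in a functional assay on PC-3 cells (Homo sapiens) for inhibition, read by sulforhodamine B assay, with a stated time of 72 h; on this read-out higher numbers stand for weaker inhibition and lower numbers for stronger inhibition
- compound 2, `CC1CCN(C(=O)c2c(N)sc(-c3ccc(Cl)cc3)c2-c2ccc(Cl)cc2)CC1`, giving 5750 nM in this assay
- compound 3, `Nc1sc(-c2ccc(Cl)cc2)c(-c2ccc(Cl)cc2)c1C(=O)NC1CCCC1`, giving 21200 nM in this assay

Among these three, compound 2 has the lowest number in this assay. Its nearest neighbour is compound 1, and that gap, a 1.3-fold lower number from compound 1 to compound 2 (0.10 log units; within the scatter), is within the scatter, so compound 2 and compound 1 cannot be ranked against each other. Compound 3 stands furthest away: a 3.7-fold higher number from compound 2 to compound 3 (0.57 log units; beyond the scatter), a modest step that is beyond the scatter, as is a 2.9-fold higher number from compound 1 to compound 3 (0.46 log units; beyond the scatter).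

Compound 4, `Nc1sc(-c2ccc(Cl)cc2)c(-c2ccc(Cl)cc2)c1C(=O)N1CCNCC1`, is not yet measured. It differs from compound 2 in one place: piperazin-1-yl in place of 4-methylpiperidin-1-yl on a carbonyl carbon.

Within the data shown here, no measured step exchanges one six-membered amine ring for another, so the bearing of the known steps is indirect. The step from compound 1 to compound 2 shows that replacing an open amide with a ring amide of this kind barely moves the number, while the step from compound 2 to compound 3 shows that shrinking the ring costs modestly. On that basis a step of at most modest size is expected for compound 4, a 1.6-fold higher number from compound 2 to compound 4 (0.19 log units; within the scatter), leaning toward a higher number. The estimate for compound 4 in this assay is therefore 9000 nM, with a range from 3000 nM to 27000 nM.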

Compound 4, half-maximal inhibitory concentration: 2710 nM
Compound 4: middle estimate off by 3.3-fold (0.52 log units), on the high side; the measured number lies below the stated range.
By their numbers in this assay, from the lowest: compound 4; then compounds 2 and 1 (each within the scatter of the next); then compound 3.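

At the carbonyl carbon, the kind of six-membered ring matters in this assay: the record gives a 2.1-fold lower number from compound 2 to compound 4 (0.33 log units; beyond the scatter) for piperazin-1-yl in place of 4-methylpiperidin-1-yl. Piperazin-1-yl also separates from both open amides, with a 2.7-fold lower number from compound 1 to compound 4 (0.43 log units; beyond the scatter) for the exchange of cyclohexylamino and a 7.8-fold lower number from compound 3 to compound 4 (0.89 log units; beyond the scatter) for the exchange of cyclopentylamino, so compound 4 now holds the lowest number of the four, with all three of its steps beyond the scatter. The earlier compounds shown here showed a cost on going from either six-membered group to cyclopentylamino, but no gain at this position, as compound 1 and compound 2 could not be ranked against each other.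

This single exchange adds a ring nitrogen and removes a methyl group at once, so the compounds shown cannot separate the two changes, and groups such as piperidin-1-yl, 4-methylpiperazin-1-yl or morpholin-4-yl at the same carbonyl carbon remain open. Nothing available explains the lower number of compound 4.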